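Methyl Removed on Two Cores at the Fatty Acid Receptor

The source may hold more compounds than are shown below. What is called first, only, known or untested is meant among the compounds shown, and "the series" means these compounds.

Compound 1, `Cc1ccccc1-c1cc(C#Cc2ccc(CCC(=O)O)cc2)ccn1`: 92%
Compound 2, `O=C(O)CCc1ccc(C#Cc2ccnc(-c3ccccc3)c2)cc1`: 97%
Compound 3, `Cc1c(C#Cc2ccc(CCC(=O)O)cc2)cc(Cl)nc1Cl`: 91%

These three values come from an in vitro functional assay on 1321-N1 cells for agonist activity at Free fatty acid receptor 1 (Homo sapiens), read by fluorescence, spectrophotometry and calcium flux; a lower number here means a smaller maximal response, a higher number a larger maximal response. Compound 2 differs from compound 1 by hydrogen in place of methyl on an aromatic carbon, and that change gave a number 5 percentage points higher from compound 1 to compound 2 (within the scatter). Compound 3 stands on a different core; how its core differs from the core of compound 1 is not broken down here, and its value and those of compound 1 and compound 2 lie within the usual scatter of one another.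

Compound 4, `O=C(O)CCc1ccc(C#Cc2cc(Cl)nc(Cl)c2)cc1`, has not been measured. It differs from compound 3 by hydrogen in place of methyl on an aromatic carbon. This is the same kind of change as that from compound 1 to compound 2, but the surroundings differ: in compound 1 the methyl sits on a six-membered aromatic ring of carbon only, ortho to a large group, whereas in compound 3 it sits on a six-membered aromatic ring with one nitrogen, ortho to a chloro group, ortho to a large group, two atoms from the ring nitrogen and para to a chloro group.

In this assay compound 4 is expected to give about 94%, between 84% and 100%. That estimate means an expected step of a number 3 percentage points higher from compound 3 to compound 4 (within the scatter), resting on the earlier step of a number 5 percentage points higher from compound 1 to compound 2 (within the scatter) and on the value of compound 3 at 91%.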

Compound 4, largest response reached (reported as efficacy), in percent of the reference or control that the assay uses: 103%
Beside the measured number, compound 4's estimate is 9 percentage points below it, and the stated range ends below it.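

In this assay, hydrogen in place of methyl on an aromatic carbon of the six-membered aromatic ring with 1 nitrogen gave a number 12 percentage points higher from compound 3 to compound 4 (beyond the scatter). The two steps do not differ beyond the scatter of two such steps, so on these two pairs the change can be read as carrying over from the core of compound 1 to the core of compound 3: the same change on two cores in this assay, a number 5 percentage points higher (within the scatter) from compound 1 to compound 2 and a number 12 percentage points higher (beyond the scatter) from compound 3 to compound 4, 7 percentage points apart, within the scatter of two such steps. This does not show that the change does more on one core than on the other, and two pairs, one with a step within the scatter, set no rule for the series.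

The compounds shown leave open whether the same holds when the methyl gives way to a different group, such as an ethyl, a methoxy or a fluoro group, on either core. They also leave open how the maximal response moves when a chloro group of compound 4 gives way to an amine.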